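Replacing Hydroxy with Nitro: What Dose to Expect

The source may report more compounds than this note shows. Statements on the series, on what has been measured and on what is new or still open speak of the compounds shown alone.

Of the compounds shown here, three built on one shared core have been measured in a functional assay on the whole organism for positive allosteric modulation, with Rattus norvegicus as the target; a lower number here means that less compound is needed, a higher number that more compound is needed for the effect. Compound 1 `Cc1nn(C)c2c1C(c1cccc(C(F)(F)F)c1)=NCCN2` gives 0.63 mg/kg. Compound 2 `Cc1nn(C)c2c1C(c1cccc(F)c1)=NCCN2` gives 2.5 mg/kg, and compound 3 `Cc1nn(C)c2c1C(c1cccc(O)c1)=NCCN2` gives 2.5 mg/kg. For the measured compounds named here, on these numbers compound 3 stands level with compound 2, the two together the highest; its only distance is to compound 1, which is a 4.0-fold higher number from compound 1 to compound 3 (0.60 log units; beyond the scatter) away. Swapping the group at this position has so far produced a 4.0-fold higher number from compound 1 to compound 2 (0.60 log units; beyond the scatter) and a 4.0-fold higher number from compound 1 to compound 3 (0.60 log units; beyond the scatter), while no change at the digits printed from compound 2 to compound 3 (within the scatter).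

Compound 4 `Cc1nn(C)c2c1C(c1cccc([N+](=O)[O-])c1)=NCCN2` differs from compound 3 by nitro in place of hydroxy on an aromatic carbon. Going by the values given here, no measured step involves nitro, so the direction is open; the measured swaps show that a change at this aromatic carbon can move this assay by a modest amount or not at all. A step of a 2.0-fold lower number from compound 3 to compound 4 (0.30 log units; within the scatter) is therefore expected, leaning toward a lower number because compound 1 with trifluoromethyl gives 0.63 mg/kg. Compound 4 is estimated at 1.25 mg/kg, within 0.4 mg/kg to 4 mg/kg.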

Compound 4, minimum effective dose: 5 mg/kg
The estimate for compound 4 lay 4.0-fold (0.60 log units) below the measured number, and the stated range ends below it.
By their numbers in this assay, from the lowest: compound 1; then compounds 2, 3 and 4 (each within the scatter of the next).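

In this assay nitro gives a 2.0-fold higher number from compound 3 to compound 4 (0.30 log units; within the scatter) and a 2.0-fold higher number from compound 2 to compound 4 (0.30 log units; within the scatter) at this aromatic carbon, so fluoro, hydroxy and nitro cannot be told apart here, even though nitro brings more heavy atoms than hydroxy and no hydrogen-bond donor. Set against trifluoromethyl, nitro gives a 7.9-fold higher number from compound 1 to compound 4 (0.90 log units; beyond the scatter) and lies beyond the scatter, so compound 1 now stands apart from all three other compounds, and swapping in a group of several heavy atoms does not by itself bring the dose down to that of compound 1. No measurement at hand offers a reason for this separation.

On these data alone, whether an amine, a carboxylic acid or a methoxy group at this aromatic carbon would fall with compound 1 or with the other three remains open. So does whether any group can need less compound than trifluoromethyl does.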